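A few compounds are considered here, and "the series" means these few. Any claim that something is new, unique, unknown or untested is made for them only; others in the source may bear on it.

Measured in a functional assay on 786-0 cells (Homo sapiens) for inhibition, read by sulforhodamine B assay, with a stated time of 48 h; a lower number here means a stronger inhibitor of growth, a higher number a weaker inhibitor of growth:

- Compound 1 `CCOC(=O)c1nn(-c2ccc(Cl)cc2)c(-c2ccc(Cl)cc2)c1CNC(C)(C)C`: 73700 nM; > 519000 nM (2 entries)
- Compound 2 `CC(C)(C)NCc1c(C(=O)O)nn(-c2ccccc2)c1-c1ccc(Cl)cc1`: > 652000 nM (a limit)
- Compound 3 `CC(C)(C)NCc1c(C(=O)O)nn(-c2ccc(Cl)cc2)c1-c1ccc(Cl)cc1`: > 599000 nM (a limit)

In this assay compound 3 gives > 599000 nM, which is a limit of the assay and not a number. It therefore has no exact position in the series. Compound 2 also gives only a limit, > 652000 nM. Among the compounds with values here, compound 1 is the only one with a number among its entries, and its other entry is a limit, as the several entries of compound 1 in this assay, 73700 nM; > 519000 nM (2 entries) shows.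

Compound 4 `CC(C)(C)NCc1c(C(=O)O)nn(-c2ccc(Cl)cc2)c1-c1ccc([N+](=O)[O-])cc1` has not yet been measured. It departs from compound 3 by nitro in place of chloro on an aromatic carbon, which is nitro in place of chloro on an aromatic carbon, turning 4-chlorophenyl into 4-nitrophenyl.

No nitro-for-chloro exchange has been measured in this small set. The nearest evidence is a step that the two limits leave unreadable from compound 2 to compound 3, a chloro in place of hydrogen on an aromatic carbon, and it gives no size to carry over. The estimate therefore stays with the limit of compound 3, (the limit of > 599000 nM in this assay, at which 1 of the 3 values shown sits), and no shift beyond the scatter is expected in either direction. The expected outcome is an at least 1.0-fold lower number from compound 3 to compound 4 (0.01 log units; that floor lies within the scatter), and a report of only a limit is likely. For compound 4 the estimated value is 585000 nM, with an expected range from 200000 nM to 800000 nM.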

Compound 4, concentration for 50% growth inhibition: 104000 nM
For compound 4 the middle estimate is 5.6-fold (0.75 log units) above the measured one; measured number below the stated range.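

In this assay, nitro in place of chloro on this aromatic carbon, turning 4-chlorophenyl into 4-nitrophenyl, gives an at least 5.7-fold lower number from compound 3 to compound 4 (0.76 log units; beyond the scatter), so this place on the shared core is one where a single exchange moves the read-out beyond the scatter. The earlier carboxylic acids offered only limits, and the one step between them cannot be read, whereas compound 4 is the only carboxylic acid shown that gives a plain number. The size of the new step remains a floor, because compound 3 gives a limit of the assay and not a number: the limit of > 599000 nM in this assay, at which 1 of the 4 values shown sits.

The compounds shown leave open whether the gain belongs to nitro in particular or would also appear with another group at this place, such as an amine or a nitrile, since a single exchange cannot tell these apart. They also leave open whether the same exchange would carry over to the ethyl ester of compound 1 in place of the carboxylic acid, and whether a change on the other 4-chlorophenyl ring of the core would have any comparable effect.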